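The source may report more compounds than this note shows. Statements on the series, on what has been measured and on what is new or still open speak of the compounds shown alone.

Three compounds share one core: compound 1 `COc1cccc(OC)c1C(=O)Nc1c[nH]nc1C(=O)NN1CCOCC1`, compound 2 `CCCCCNC(=O)c1n[nH]cc1NC(=O)c1c(OC)cccc1OC` and compound 3 `COc1cccc(OC)c1C(=O)Nc1c[nH]nc1C(=O)NCC1CCCCC1`. In an ADME assay on MRC5 cells (Homo sapiens) for inhibition, with a stated time of 72 h (on this read-out lower numbers stand for an effect already at smaller amounts and higher numbers for an effect only at larger amounts of compound), compound 1 reaches only the limit > 50000 nM. Compound 2 likewise gives only the limit > 50000 nM. Compound 3 too stops at the limit > 50000 nM. All three thus sit at the limit of > 50000 nM in this assay, at which 3 of the 3 values shown sit, and compound 3 stands nowhere above or below its companions. The steps among them are therefore a step that the two limits leave unreadable from compound 1 to compound 2, a step that the two limits leave unreadable from compound 1 to compound 3 and a step that the two limits leave unreadable from compound 2 to compound 3. Compound 4 `COc1cccc(OC)c1C(=O)Nc1c[nH]nc1C(=O)NC1CC2CCC1C2` differs from compound 3 by a group of 7 heavy atoms (7 carbon; 2 five-membered non-aromatic rings of carbon only) in place of a group of 7 heavy atoms (7 carbon; one six-membered non-aromatic ring of carbon only), on an amide-type nitrogen. Within the data shown here, no measured step reports a size, so no direction beyond the scatter is expected for a step that the limit leaves unreadable from compound 3 to compound 4. Compound 4 is therefore estimated at 60000 nM, between 30000 nM and 120000 nM, most likely once more only a limit.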

Compound 4, half-maximal effective concentration: > 50000 nM
Compound 4: no number, only a limit; the forecaster's own chance of this, stated with the estimate: 85%; the middle value lies beyond the limit too.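

Compound 4 adds no readable step to compound 1, compound 2 and compound 3, because all four stop at a limit: the limit of > 50000 nM in this assay, at which 4 of the 4 values shown sit. Whether the group on the amide-type nitrogen matters at all in this assay stays open: no compound shown gives a number.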